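Moving the methoxy group: from compound 1 to compound 3

This account rests on a few compounds, and the source may have more. Where it says the series, first, only, none or still open, it means among the compounds named here.

Among the measured compounds shown here, compound 1 `CCCN(CC[C@H]1CC[C@H](NC(=O)/C=C/c2ccc(Cl)cc2)CC1)[C@H]1CCc2nc(N)sc2C1` gives 2.5 nM in an assay on brain for displacement of a labelled ligand from D(3) dopamine receptor (Rattus norvegicus) (a higher number here means a weaker inhibitor, a lower number a stronger inhibitor), the lower of the two numbers measured so far. Compound 2 `CCCN(CC[C@H]1CC[C@H](NC(=O)/C=C/c2cccc(OC)c2)CC1)[C@H]1CCc2nc(N)sc2C1` gives 9.3 nM in this assay, and the step of a 3.7-fold higher number from compound 1 to compound 2 (0.57 log units; beyond the scatter) is small but clearly beyond the scatter. Compound 3 `CCCN(CC[C@H]1CC[C@H](NC(=O)/C=C/c2ccccc2OC)CC1)[C@H]1CCc2nc(N)sc2C1` carries a related change: 2-methoxyphenyl in place of 4-chlorophenyl on a double-bonded chain carbon bound to a double-bonded chain carbon. For the measured compounds named here, the only measured step that bears on this is the one just described, so a comparable weakening is expected, and the estimated step is a 3.2-fold higher number from compound 1 to compound 3 (0.51 log units; beyond the scatter). Compound 3 is therefore expected to give about 8 nM in this assay, with a likely range from 2.5 nM to 30 nM.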

Compound 3, inhibition constant: 8.1 nM
Beside the measured number, compound 3's estimate is 1.0-fold (0.01 log units) below it; measured number inside the range.
By their numbers in this assay, from the lowest: compound 1; then compounds 3 and 2 (each within the scatter of the next).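

In this assay, 2-methoxyphenyl in place of 4-chlorophenyl again weakens binding (a 3.2-fold higher number from compound 1 to compound 3 (0.51 log units; beyond the scatter)), so this loss is not confined to the 3-methoxyphenyl group of compound 2. Swapping 3-methoxyphenyl for 2-methoxyphenyl changes nothing that can be told apart (a 1.1-fold lower number from compound 2 to compound 3 (0.06 log units; within the scatter)), so these two placements of the methoxy group are equivalent here. No measurement shown explains either step. On these data alone, it remains open how 4-methoxyphenyl would compare, which would show whether the methoxy group itself or its placement separates these compounds from compound 1. A 2-chlorophenyl or 3-chlorophenyl group would test the same question from the chlorine side.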